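This account rests on a few compounds, and the source may have more. Where it says the series, first, only, none or still open, it means among the compounds named here.

Compound 1 `CC(C)CCn1nc(C(=O)N[C@H]2COc3ccccc3N(C)C2=S)nc1Cc1ccccc1` gives 3640 nM
Compound 2 `CN1C(=S)[C@@H](NC(=O)c2nc(Cc3ccccc3)n(CCCC(F)(F)F)n2)COc2ccccc21` gives 2380 nM
Compound 3 `CN1C(=S)[C@@H](NC(=O)c2nc(Cc3ccccc3)n(CCCC#N)n2)COc2ccccc21` gives 2400 nM

All three numbers come from a functional assay on HT-29 cells (Homo sapiens) for inhibition, read by luminescence and CellTiter-Glo, with a stated time of 24 h (a lower number here means that less compound is needed, a higher number that more compound is needed for the effect), and the compounds share a core, differing only in the chain on an aromatic nitrogen. Compound 3 with 2400 nM is not separated from the other two. The measured steps read a 1.5-fold lower number from compound 1 to compound 3 (0.18 log units; within the scatter) and a 1.0-fold higher number from compound 2 to compound 3 (0.00 log units; within the scatter) and also a 1.5-fold lower number from compound 1 to compound 2 (0.18 log units; within the scatter) with none of them beyond the scatter.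

Compound 4 `CN1C(=S)[C@@H](NC(=O)c2nc(Cc3ccccc3)n(CCCCCC#N)n2)COc2ccccc21` keeps everything in compound 3 except the end of this chain. The difference is (2-cyanoethyl in place of cyano on a saturated chain carbon, three bonds along the chain from an aromatic nitrogen). In words, this is 2-cyanoethyl in place of cyano on a saturated chain carbon, three bonds along the chain from an aromatic nitrogen. The nitrile stays and the chain grows longer.

For the measured compounds named here, no measured pair tests a longer chain with the nitrile kept, so the evidence is indirect. Going by the values given here, the three steps above all changed this chain, and each stayed small, including a 1.0-fold higher number from compound 2 to compound 3 (0.00 log units; within the scatter) as the one closest to compound 3. No step beyond the scatter is therefore expected in this assay and the expected size is a 1.1-fold higher number from compound 3 to compound 4 (0.03 log units; within the scatter) in either direction. Compound 4 is estimated at 2600 nM with an expected range from 1200 nM to 5500 nM in this measurement.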

Compound 4, half-maximal effective concentration: 3830 nM
Estimate against measurement, compound 4: 1.5-fold (0.17 log units) below; measured number inside the range.
By their numbers in this assay, from the lowest: compounds 2, 3, 1 and 4 (each within the scatter of the next).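

In this assay, going from 3-cyanopropyl to 5-cyanopentyl with the nitrile kept at the chain end gives a 1.6-fold higher number from compound 3 to compound 4 (0.20 log units; within the scatter), so this longer chain produces no step beyond the scatter. The comparisons with the two chains that carry no nitrile read the same way, with a 1.6-fold higher number from compound 2 to compound 4 (0.21 log units; within the scatter) and a 1.1-fold higher number from compound 1 to compound 4 (0.02 log units; within the scatter), so across these four chains, which differ in length and in their end group, none of the steps at this position stands out from the scatter. Nothing else available here speaks to what lies behind these closely grouped numbers.

As far as these compounds go, all four chains are open and end in an isopropyl, a trifluoromethyl or a nitrile, so it remains open whether the number would stay in the same region with an amine or a carboxylic acid at the chain end, or with a phenyl ring there. From the compounds shown here alone, it is also open whether a still longer chain, or a much shorter one such as a plain methyl on the aromatic nitrogen, would produce a step beyond the scatter.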